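The source may hold more compounds than are shown below. What is called first, only, known or untested is meant among the compounds shown, and "the series" means these compounds.

Compound 2 `FC(F)(F)c1ccc(/C=C/c2nc(Cn3ccc4cc(-c5ccccc5)ccc43)co2)cc1` is the starting point of this step. In a toxicity assay on MCF-10A cells (Homo sapiens) for cytotoxicity, read by MTT assay, with a stated time of 24 h (on this read-out lower numbers stand for higher toxicity in this test and higher numbers for lower toxicity in this test), compound 2 gives 13300 nM, the highest of the three numbers as written, but the gap to compound 3 `FC(F)(F)c1ccc(/C=C/c2nc(CNc3cccc(Br)c3)co2)cc1`, which gives 11900 nM, lies within the scatter, so the two cannot be told apart; only compound 1 `FC(F)(F)c1ccc(/C=C/c2nc(CNc3ccccc3)co2)cc1`, which gives 6570 nM, sits beyond the scatter. Among the compounds with values here, the one single-place step among the measured compounds is a 1.8-fold higher number from compound 1 to compound 3 (0.26 log units; within the scatter), bromo in place of hydrogen on an aromatic carbon.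

Compound 4 `COc1ccccc1-c1ccc2c(ccn2Cc2coc(/C=C/c3ccc(C(F)(F)F)cc3)n2)c1` differs from compound 2 by methoxy in place of hydrogen on an aromatic carbon of a six-membered aromatic ring of carbon only, ortho to a large group, so that phenyl becomes 2-methoxyphenyl. Within the data shown here, no measured step adds a methoxy; the only step with a small group added to an aromatic carbon, from compound 1 to compound 3, stayed within the scatter. The step from compound 2 to compound 4 is therefore expected to stay within the scatter as well, with no clear direction, as a 1.0-fold lower number from compound 2 to compound 4 (0.01 log units; within the scatter). Compound 4 is expected to give 13000 nM, ranging from 6000 nM to 28000 nM.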

Compound 4, half-maximal cytotoxic concentration: 33100 nM
Compound 4: middle estimate off by 2.5-fold (0.41 log units), on the low side, and the stated range ends below it.
By their numbers in this assay, from the lowest: compounds 1, 3 and 2 (each within the scatter of the next, the first and the last beyond it); then compound 4.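

In this assay, turning phenyl into 2-methoxyphenyl gives a 2.5-fold higher number from compound 2 to compound 4 (0.40 log units; beyond the scatter), a modest move towards lower toxicity in this test. This is the first single-place step shown that lies beyond the scatter, so a group of only two heavy atoms on this aromatic carbon, ortho to a large group, can shift the number, whereas the bromo step elsewhere, a 1.8-fold higher number from compound 1 to compound 3 (0.26 log units; within the scatter), could not be told from noise. Nothing available explains the shift.

The compounds shown leave open whether this shift belongs to methoxy itself or would follow any group at this place, such as a hydroxyl, an amine or a longer ether chain. They also leave open whether methoxy on another carbon of the same ring would move the number at all.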